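The compounds below may be only part of what the source reports. "The series", "measured", "known", "first", "only" and "open" are said of these compounds alone.

Measured compounds in a functional assay on MKN-45 cells (Homo sapiens) for cytotoxicity, read by MTT assay, with a stated time of 72 h; a higher number here means a weaker inhibitor, a lower number a stronger inhibitor:
compound 1 `COc1cc2c(Oc3ccc(NC(=O)c4nccc(-c5ccc(C)cc5)n4)cc3F)ccnc2cc1OCCCN1CCCCC1` gives 580 nM
compound 2 `COc1cc2c(Oc3ccc(NC(=O)c4nccc(-c5ccc(F)cc5)n4)cc3F)ccnc2cc1OCCCN1CCCCC1` gives 930 nM

Among the compounds with values here, compound 2 stands beside compound 1, the only other measured compound, and the change from compound 1 to compound 2, fluoro in place of methyl on an aromatic carbon, amounts to a 1.6-fold higher number from compound 1 to compound 2 (0.21 log units; within the scatter). Compound 3 `COc1cc2c(Oc3ccc(NC(=O)c4nccc(-c5ccc(F)cc5)n4)cc3F)ccnc2cc1OCCCN1CCCC1` differs from compound 2 by pyrrolidin-1-yl in place of piperidin-1-yl on a saturated chain carbon, three bonds along the chain from an oxygen on an aromatic ring. Within the data shown here, no measured step touches this part of the molecule; the single step that exists concerns a substituent elsewhere. Nothing in the data therefore points in either direction, and the step from compound 2 to compound 3 is expected to stay within the scatter, a 1.0-fold lower number from compound 2 to compound 3 (0.01 log units; within the scatter). Compound 3 is estimated at 900 nM in this assay, with a range from 400 nM to 2000 nM.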

Compound 3, half-maximal inhibitory concentration: 490 nM
Beside the measured number, compound 3's estimate is 1.8-fold (0.26 log units) above it; low and high end bracket the measured number.
By their numbers in this assay, from the lowest: compounds 3, 1 and 2 (each within the scatter of the next).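

In this assay, within the data shown here, the first step at this position, pyrrolidin-1-yl in place of piperidin-1-yl, gives a 1.9-fold lower number from compound 2 to compound 3 (0.28 log units; within the scatter) and so stays within the scatter. At the end of the propyl chain, the five-membered ring thus serves in this assay about as well as the six-membered one. The data offer no reason for the size of this step. As far as these compounds go, whether morpholin-4-yl or dimethylamino would hold up equally well at this place remains open. So does whether a longer chain would change the number, and whether the same exchange would behave alike with the methyl group of compound 1.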